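A few compounds are considered here, and "the series" means these few. Any claim that something is new, unique, unknown or untested is made for them only; others in the source may bear on it.

Measured compounds in a functional assay on the whole organism for inhibition, with Rattus norvegicus as the target, at a dose of 10 mg/kg by the oral route; a lower number here means a weaker effect, a higher number a stronger effect of the compound at the dose given:
- compound 1 `COc1cc(C(=O)Nc2nn[nH]n2)nc(-c2ccccc2)c1` gives 100%
- compound 2 `COc1cc(C(=O)Nc2nn[nH]n2)nc(-c2cccc(Cl)c2)c1` gives 64%
- compound 3 `COc1cc(C(=O)Nc2nn[nH]n2)nc(-c2ccc(OC)c(OC)c2)c1` gives 51%

Compound 1 stands highest of the three in this assay; its steps to compound 2 and to compound 3 both lie beyond the scatter, so it is the strongest of the measured set. Compound 3 differs from compound 1 in more than one place, so only its two values can be compared, and they show compound 3 well under compound 1.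

The unmeasured compound 4 `CCCCc1ccc(-c2cc(OC)cc(C(=O)Nc3nn[nH]n3)n2)cc1` arises from compound 1 by butyl in place of hydrogen on an aromatic carbon.

Among the compounds with values here, only one measured step bears on this change: a number 36 percentage points lower from compound 1 to compound 2 (beyond the scatter), a large loss after a single substituent entered the same six-membered aromatic ring of carbon only. Butyl is a different group at a different place, so the bearing is loose, but the one comparison available points downward, and compound 3 carrying two substituents on that ring is also far below compound 1. A step downward is therefore expected in this assay, of the order of a number 45 percentage points lower from compound 1 to compound 4 (beyond the scatter). Compound 4 is estimated at 55%, within a range from 25% to 90%.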

Compound 4, a percentage reported as inhibition, in the whole organism at one dose (the size of the read-out at that dose, not a potency): 92%
Estimate against measurement, compound 4: 37 percentage points below; measured number above the stated range.
By their numbers in this assay, from the lowest: compound 3; then compound 2; then compounds 4 and 1 (each within the scatter of the next).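

With butyl para to a large group, the step of a number 8 percentage points lower from compound 1 to compound 4 (within the scatter) shows that this place on the six-membered aromatic ring of carbon only can carry a substituent in this assay without a loss beyond the scatter. A substituent on this ring therefore does not by itself bring the large drop seen in the step of a number 36 percentage points lower from compound 1 to compound 2 (beyond the scatter), although chloro and butyl differ both as groups and in where they sit, so the two steps cannot be set against each other directly. Nothing at hand offers a reason for this result.

Open, going by these compounds, is whether a longer chain, a tert-butyl group, an amine or a carboxylic acid at this same place would keep the effect. The read-out at one dose also leaves open whether compound 1 and compound 4 would separate at lower doses.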